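Hydrazone series against maltase-glucoamylase: notes before compound 3

The source may hold more compounds than are shown below. What is called first, only, known or untested is meant among the compounds shown, and "the series" means these compounds.

Measured so far:
compound 1 `COC(=O)c1ccc(/C=N/NC(=O)c2ccc(-c3nc4ccccc4s3)cc2)cc1` — "not active" (no number reported)
compound 2 `O=C(N/N=C/c1ccc(F)c(Br)c1)c1ccc(-c2nc3ccccc3s2)cc1` — 28000 nM

In an assay on isolated protein for inhibition of Maltase-glucoamylase (Homo sapiens), with a stated time of 15 min (a lower number here means a stronger inhibitor, a higher number a weaker inhibitor), compound 1 gives "not active" (no number reported), so no number stands for it. In this assay compound 2 gives 28000 nM, a weak result. For the measured compounds named here, no step between the two measured compounds is laid out, so what the pair shows is only that both sit at the weak end of the range. Compound 3 `O=C(N/N=C/c1ccncc1)c1ccc(-c2nc3ccccc3s2)cc1` is the next member to be measured. It differs from compound 1 in one place: pyridin-4-yl in place of 4-(methoxycarbonyl)phenyl on a carbon with a double bond to nitrogen. With compound 1 having no number in this assay, the size of the step cannot be stated, and no direction is expected beyond the scatter. Compound 3 is expected in this assay to give about 40000 nM, with a range from 8000 nM to 200000 nM, and a real chance that only a limit is returned.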

Compound 3, half-maximal inhibitory concentration: "not active" (no number reported)
Compound 3: no number reported; the estimate stays without a comparison.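

For the compounds shown here, compound 3, like compound 1, has no number in this assay and so no step between the two can be read. No measured evidence bears on this result. The compounds shown leave open whether pyridin-4-yl and 4-(methoxycarbonyl)phenyl differ in their effect on inhibition.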